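Pyrazine hydrazone series: para substitution on the benzylidene ring

The compounds below may be only part of what the source reports. "The series", "measured", "known", "first", "only" and "open" are said of these compounds alone.

Compound 3 `O=C(N/N=C/c1ccccc1)c1cnccn1` stands lowest of the three numbers in a functional assay on the whole organism (strain Swiss) for inhibition, with Mus musculus as the target, read by paw edema, with stated times of 40 min and 30 min, at a dose of 100 umol/kg by the oral route (on this read-out higher numbers stand for more inhibition at the one dose given (going by the name of the read-out) and lower numbers for less inhibition), giving 30.5%. Its nearest neighbour is compound 1 `O=C(N/N=C/c1ccc(O)cc1)c1cnccn1`, which gives 42.3%; furthest is compound 2 `COc1ccc(/C=N/NC(=O)c2cnccn2)cc1OC`, which gives 49.6%. Going by the values given here, the only single-point step among the measured compounds, a number 11.8 percentage points lower from compound 1 to compound 3 (beyond the scatter), shows that removing the hydroxy group costs activity beyond the scatter. Among the compounds with values here, compound 2 differs from compound 3 in two places, so its higher value is noted but yields no isolated step.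

Compound 4 `O=C(N/N=C/c1ccc(C(F)(F)F)cc1)c1cnccn1` differs from compound 3 by trifluoromethyl in place of hydrogen on an aromatic carbon, placed on an aromatic carbon of the six-membered carbon ring, para to a large group. Within the data shown here, no measured step involves trifluoromethyl; the only step at this position, hydroxy in place of hydrogen, was modest and positive. On that slender basis a small rise is expected for compound 4, a number 7.5 percentage points higher from compound 3 to compound 4 (within the scatter), possibly within the scatter. Compound 4 is therefore estimated at 38%, with a range of 26% to 50%.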

Compound 4, a percentage reported as inhibition, in the whole organism at one dose (the size of the read-out at that dose, not a potency): 48.3%
Compound 4: middle estimate off by 10.3 percentage points, on the low side, within the range that was stated.
By their numbers in this assay, from the lowest: compound 3; then compounds 1, 4 and 2 (each within the scatter of the next).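

In this assay, the step with a number 17.8 percentage points higher from compound 3 to compound 4 (beyond the scatter) gives this position a second group that stands clear of hydrogen, so the earlier gain is no longer tied to hydroxy alone. Exchanging hydroxy for trifluoromethyl, with a number 6 percentage points higher from compound 1 to compound 4 (within the scatter), leaves the two groups indistinguishable on this read-out, even though trifluoromethyl carries no hydrogen-bond donors or acceptors. No supporting data are available to explain this result.

On these data alone, only hydrogen, hydroxy and trifluoromethyl can be compared at this position, so it remains open whether an amine, a carboxylic acid or a longer alkyl chain would stand with hydroxy and trifluoromethyl or with hydrogen. A single methoxy group here would also be needed to connect compound 2 to the series through one-place steps.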